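Chloro to Methoxy Swap: an Antiproliferative Expectation

This account rests on a few compounds, and the source may have more. Where it says the series, first, only, none or still open, it means among the compounds named here.

Measured so far:
compound 1, `COc1ccc(-c2nc(SCC(=O)c3sc(-c4ccccc4)nc3C)[nH]c(=O)c2C#N)cc1`: 97.3%
compound 2, `COc1ccc(-c2nc(C)c(C(=O)CSc3nc(-c4ccc(Cl)cc4)c(C#N)c(=O)[nH]3)s2)cc1`: 102%

Both numbers come from a functional assay on U-87MG ATCC cells for antiproliferative activity against U-87 MG (Homo sapiens), read by MTT assay, with a stated time of 48 h, tested at 5 uM; on this read-out lower numbers stand for a stronger effect and higher numbers for a weaker effect at the one concentration tested. Compound 2 stands highest of the two numbers, and its nearest neighbour is compound 1, whose value lies within the scatter of it; the two therefore read alike, and both sit close to the untreated level. Going by the values given here, compound 1 and compound 2 differ in more than one place, so no single step between them can be drawn.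

Compound 3, `COc1ccc(-c2nc(C)c(C(=O)CSc3nc(-c4ccc(OC)cc4)c(C#N)c(=O)[nH]3)s2)cc1`, has not yet been measured. It differs from compound 2 by methoxy in place of chloro on an aromatic carbon. Among the compounds with values here, nothing among the measured compounds isolates this change, so no step beyond the scatter is expected in this assay in either direction. Compound 3 is accordingly expected to give 99%, within 88% to 108%. The estimated step from compound 2 to compound 3 is a number 3 percentage points lower from compound 2 to compound 3 (within the scatter), an expectation of no real change.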

Compound 3, a percentage reported as activity, at one concentration (the size of the read-out at that concentration, not a potency): 97%
For compound 3 the middle estimate is 2 percentage points above the measured one, and the stated range covers the measured number.
By their numbers in this assay, from the lowest: compounds 3, 1 and 2 (each within the scatter of the next).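

In this assay, going from 4-chlorophenyl to 4-methoxyphenyl gives a number 5 percentage points lower from compound 2 to compound 3 (within the scatter), so at this place, para to a large group, methoxy and chloro read alike. The second comparison in one place, where a methoxy group takes the place of a hydrogen of an aromatic ring, gives a number 0.3 percentage points lower from compound 1 to compound 3 (within the scatter), so this change also leaves the read-out where it was. Nothing measured here speaks to why these compounds read as they do.

With no step beyond the scatter among these compounds, it remains open whether any group at this place can move the read-out at all. Whether an amine, a carboxylic acid or a longer alkoxy chain in place of methoxy would read differently, or a change elsewhere on the shared core, is also left open.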